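Cyclobutylamino for methoxy on the quinoline core

This account rests on a few compounds, and the source may have more. Where it says the series, first, only, none or still open, it means among the compounds named here.

Measured compounds:
compound 1, `CCCc1cc(N)c2cc(NC(=O)/C=C/c3ccc(Cl)cc3)ccc2n1`, 6 nM
compound 2, `CCCc1cc(OC)c2cc(NC(=O)/C=C/c3ccc(C(F)(F)F)cc3)ccc2n1`, 26 nM
compound 3, `CCCc1cc(N)c2cc(NC(=O)/C=C/c3ccc(CC)cc3)ccc2n1`, 1.4 nM

In an assay on isolated protein for displacement of a labelled ligand from melanin-concentrating hormone receptor 1 (Homo sapiens) (on this read-out higher numbers stand for weaker inhibition and lower numbers for stronger inhibition), compound 2 shows the highest number of the three, with compound 1 nearest and compound 3 furthest. Compound 4, `CCCc1cc(NC2CCC2)c2cc(NC(=O)/C=C/c3ccc(C(F)(F)F)cc3)ccc2n1`, differs from compound 2 by cyclobutylamino in place of methoxy on an aromatic carbon. Going by the values given here, the only single-point step measured, a 4.3-fold lower number from compound 1 to compound 3 (0.63 log units; beyond the scatter), concerns a different position and does not bear on this change. Compound 1 and compound 2 differ in two places at once, so their values tell little about this position alone. Compound 4 is therefore expected to give 12 nM in this assay, within 3 nM to 50 nM. The expected step is a 2.2-fold lower number from compound 2 to compound 4 (0.34 log units; beyond the scatter), a cautious guess at a modestly lower number.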

Compound 4, half-maximal inhibitory concentration: 18 nM
For compound 4 the middle estimate is 1.5-fold (0.18 log units) below the measured one, and the stated range covers the measured number.
By their numbers in this assay, from the lowest: compound 3; then compound 1; then compounds 4 and 2 (each within the scatter of the next).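

In this assay, cyclobutylamino in place of methoxy on this aromatic carbon, opposite the ring nitrogen, gives a 1.4-fold lower number from compound 2 to compound 4 (0.16 log units; within the scatter). The position thus takes on a four-membered ring of carbon only and a hydrogen-bond donor with no change that stands out from the scatter. Nothing available explains this result.

The compounds shown leave open how the plain amino group of compound 1 would read with trifluoromethyl on the other aromatic ring. They also leave open whether a dimethylamino group or a morpholine on this carbon would read the same.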